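Swapping the piperazine cap in a cytotoxicity series

The compounds below may be only part of what the source reports. "The series", "measured", "known", "first", "only" and "open" are said of these compounds alone.

Compound 1 `CCOC(=O)/C=C/c1cnc(Nc2ccc(C#N)cc2)nc1Oc1c(C)cc(C#N)cc1C` and compound 2 `Cc1cc(C#N)cc(C)c1Oc1nc(Nc2ccc(C#N)cc2)ncc1/C=C/C(=O)N1CCN(S(C)(=O)=O)CC1` share one core and differ only at the carbonyl carbon, where an ethoxy gives way to a 4-(methylsulfonyl)piperazin-1-yl. In an ADME assay on TZM cells (Homo sapiens) for cytotoxicity, with a stated time of 1 days (a higher number here means that more compound is tolerated, a lower number that less compound is tolerated), compound 1 reaches only a limit, > 227 nM. Compound 2 likewise reaches only a limit in this assay, > 179 nM. The step that the two limits leave unreadable from compound 1 to compound 2 cannot be sized because the limit of > 179 nM in this assay, at which 1 of the 2 values shown sits, and the limit of > 227 nM in this assay, at which 1 of the 2 values shown sits, are both limits.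

Compound 3 `Cc1cc(C#N)cc(C)c1Oc1nc(Nc2ccc(C#N)cc2)ncc1/C=C/C(=O)N1CCN(C=O)CC1` differs from compound 2 by formyl in place of methylsulfonyl on an amine nitrogen in a ring. Among the measured compounds shown here, no measured step touches this amine nitrogen, and the single step in hand is unreadable, so it lends no size or direction to the expectation. Compound 3 is therefore expected to sit again at the edge of this assay, estimated at 200 nM with a range from 100 nM to 400 nM. The expected step that the limit leaves unreadable from compound 2 to compound 3 is thus no larger than the scatter, and a limit rather than a number is the likelier outcome.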

Compound 3, half-maximal cytotoxic concentration: > 197 nM
Compound 3: only a limit was reported (the forecaster's own chance of this, stated with the estimate: 80%); the middle value lies beyond the limit too.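

Compound 3 also reaches only a limit, so neither its step from compound 2 nor its step from compound 1 can be read. The compounds shown leave open the actual half-maximal cytotoxic concentration of all three in this assay, and whether the piperazine cap matters there at all.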